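Phenyl in place of chloromethyl on a selenazole hydrazone

The source may report more compounds than this note shows. Statements on the series, on what has been measured and on what is new or still open speak of the compounds shown alone.

Compound 3 `CC(=O)N(/N=C/c1ccc(Cl)cc1)c1nc(CCl)c[se]1` gives in a functional assay on HepG2 cells (Homo sapiens) for cytotoxicity, read by XTT assay, with a stated time of 72 h (on this read-out higher numbers stand for weaker inhibition and lower numbers for stronger inhibition), only a limit, > 66600 nM. Its parent compound 2 `CC(=O)N(/N=C/c1ccc(Cl)cc1)c1nc(C)c[se]1` gives 59200 nM, and the step of an at least 1.1-fold higher number from compound 2 to compound 3 (0.05 log units; that floor lies within the scatter) is too small to read as a change. Compound 1 `Clc1ccc(/C=N/Nc2nc(-c3ccccc3)c[se]2)cc1`, which carries a phenyl on the shared core, gives 42500 nM. Compound 4 `CC(=O)N(/N=C/c1ccc(Cl)cc1)c1nc(-c2ccccc2)c[se]1` differs from compound 3 by phenyl in place of chloromethyl on an aromatic carbon. For the measured compounds named here, no measured step covers this exact change; the limit of > 66600 nM in this assay, at which 1 of the 3 values shown sits, only sets a floor for compound 3. For compound 4 the expected step of an at least 1.2-fold lower number from compound 3 to compound 4 (0.08 log units; that floor lies within the scatter) is therefore small, within the scatter. Compound 4 is estimated at 55000 nM, with a likely range from 25000 nM to 120000 nM.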

Compound 4, half-maximal inhibitory concentration: > 62000 nM
Compound 4: no number, only a limit; the forecaster's own chance of this, stated with the estimate: 40%; at least 1.1-fold (0.05 log units) between middle value and limit.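

In this assay compound 4 gives only a limit, > 62000 nM. Phenyl in place of methyl gives an at least 1.0-fold higher number from compound 2 to compound 4 (0.02 log units; that floor lies within the scatter), and acetyl on the nitrogen gives an at least 1.4-fold higher number from compound 1 to compound 4 (0.16 log units; that floor lies within the scatter), so neither change can yet be read as having any effect at this position or on that nitrogen. The step between the two limits of compound 3 and compound 4 cannot be read at all.

Going by these compounds, the true values behind those two limits remain open. So does whether an amine or a carboxylic acid on this aromatic carbon would give a measurable number.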